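Lengthening the Hydroxamic Acid Chain by One More Carbon

The compounds below may be only part of what the source reports. "The series", "measured", "known", "first", "only" and "open" are said of these compounds alone.

- Compound 1 `O=C(CCCC(=O)Nc1ccc(NC(=O)Nc2ccc(Cl)c(C(F)(F)F)c2)cc1)NO`: > 10000 nM, a limit
- Compound 2 `O=C(CCCCC(=O)Nc1ccc(NC(=O)Nc2ccc(Cl)c(C(F)(F)F)c2)cc1)NO`: > 10000 nM, a limit
- Compound 3 `O=C(CCCCCC(=O)Nc1ccc(NC(=O)Nc2ccc(Cl)c(C(F)(F)F)c2)cc1)NO`: > 10000 nM, a limit

In a functional assay on PC-3 cells (Homo sapiens) for inhibition, read by sulforhodamine B assay, with a stated time of 48 h (on this read-out higher numbers stand for weaker inhibition and lower numbers for stronger inhibition), compound 3 gives > 10000 nM, which is a limit and not a number. It shares this position with the other two compounds: the limit of > 10000 nM in this assay, at which 3 of the 3 values shown sit.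

Compound 4 `O=C(CCCCCCC(=O)Nc1ccc(NC(=O)Nc2ccc(Cl)c(C(F)(F)F)c2)cc1)NO` differs from compound 3 by one change: (hydroxycarbamoyl)methyl in place of hydroxycarbamoyl on a saturated chain carbon, five bonds along the chain from a carbonyl carbon. In words, this is (hydroxycarbamoyl)methyl in place of hydroxycarbamoyl on a saturated chain carbon, five bonds along the chain from a carbonyl carbon.

The same kind of change links the measured compounds: a step that the two limits leave unreadable from compound 1 to compound 2 and a step that the two limits leave unreadable from compound 2 to compound 3. Taken together, the two changes give a step that the two limits leave unreadable from compound 1 to compound 3. None of these steps has a readable size, so they indicate no direction. No step beyond the usual scatter is therefore expected, and this assay may again report only a limit.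

The estimated step is a step that the limit leaves unreadable from compound 3 to compound 4.

For compound 4 the expected value is 12000 nM, with an estimated range of 3000 nM to 40000 nM.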

Compound 4, half-maximal inhibitory concentration: 4600 nM
Compound 4: middle estimate off by 2.6-fold (0.42 log units), on the high side, and the stated range covers the measured number.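

In this assay, among the compounds shown here, this one-carbon extension gives the first step whose size can be partly read: an at least 2.1-fold lower number from compound 3 to compound 4 (0.33 log units; beyond the scatter). The comparison with the shorter chains points the same way, with an at least 2.1-fold lower number from compound 2 to compound 4 (0.33 log units; beyond the scatter) and an at least 2.1-fold lower number from compound 1 to compound 4 (0.33 log units; beyond the scatter), while the steps among compound 1, compound 2 and compound 3 cannot be read. Chain length at this position can therefore move the number, and compound 4 alone sits off the limit shared by the other compounds: the limit of > 10000 nM in this assay, at which 3 of the 4 values shown sit.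

The shorter compounds carry only limits, which leaves the true size of these steps open. Also open, as far as these compounds go, is whether a still longer chain would lower the number further, and whether a carboxylic acid in place of the hydroxycarbamoyl end would keep the change seen with compound 4.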